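Methoxy added to the aryl ketone side of the series

The source may report more compounds than this note shows. Statements on the series, on what has been measured and on what is new or still open speak of the compounds shown alone.

Three compounds have numbers in a functional assay on UO-31 cells (Homo sapiens) for cytotoxicity, read by sulforhodamine B assay, with a stated time of 48 h, tested at 1 uM; a higher number here means a weaker effect of the compound at the concentration tested, a lower number a stronger effect. Compound 1 `COc1ccc(-c2cc(/C=C/C(=O)c3ccc(N)cc3)[nH]n2)cc1` gives 61%. Compound 3 `COc1ccc(-c2cc(/C=C/C(=O)c3ccc(N)cc3)[nH]n2)cc1OC` differs from compound 1 by methoxy in place of hydrogen on an aromatic carbon; in this assay compound 3 gives 86%. That change made a step of a number 25 percentage points higher from compound 1 to compound 3 (beyond the scatter). Compound 2 `COc1ccc(C(=O)/C=C/c2cc(-c3cc(OC)c(OC)c(OC)c3)n[nH]2)cc1OC` carries a different core; the difference between the cores of compound 1 and compound 2 is not broken down here. In this assay compound 2 gives 67%, a number within the scatter of compound 1 and beyond the scatter from compound 3.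

Compound 4 `COc1cc(C(=O)/C=C/c2cc(-c3cc(OC)c(OC)c(OC)c3)n[nH]2)cc(OC)c1OC` is not yet measured. It differs from compound 2 by methoxy in place of hydrogen on an aromatic carbon. This is the same kind of change as from compound 1 to compound 3, but not the same: the place for compound 4 is ortho to a methoxy group, meta to a large group and meta to a methoxy group, whereas for compound 3 the place is ortho to a methoxy group and meta to a large group only.

Among the compounds with values here, only one earlier instance of this change exists, so the expectation rests on a single step. For compound 4 the step from compound 2 is estimated as a number 17 percentage points higher from compound 2 to compound 4 (beyond the scatter), placed beside the earlier step because compound 1 to compound 3 gave a number 25 percentage points higher from compound 1 to compound 3 (beyond the scatter) and because compound 2 starts from 67%, leaving less room upward than compound 1 had. Compound 4 is therefore expected to give about 84% in this assay, most likely between 68% and 98%.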

Compound 4, a percentage reported as activity, at one concentration (the size of the read-out at that concentration, not a potency): 62%
The estimate for compound 4 lay 22 percentage points above the measured number; measured number below the stated range.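

The methoxy change does not carry over from one core to the other as a fixed step in this assay: the same change on two cores in this assay, a number 25 percentage points higher (beyond the scatter) from compound 1 to compound 3 and a number 5 percentage points lower (within the scatter) from compound 2 to compound 4, 30 percentage points apart, beyond the scatter of two such steps. On the core of compound 2 it gives a number 5 percentage points lower from compound 2 to compound 4 (within the scatter), so the clear shift seen on the core of compound 1 does not reappear here, and a step read on one core gives no safe estimate for the other. This does not show what sets the two steps apart, since the two pairs differ in their cores and also in the place of the new methoxy, which in compound 4 is meta to a further methoxy group, and two pairs at a single concentration cannot separate these differences or give a rule for the wider series.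

Still open, on these data alone, is whether the change would behave the same way at a matching place on both cores, which would need a pair on each core with the same surroundings around the new group. Also open, as far as these compounds go, is whether a hydroxy group or a longer chain such as ethoxy in place of that hydrogen would follow the step of compound 3 or that of compound 4, and how the amine of compound 1 and compound 3 would fare on the other core.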